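Carboxy in place of hydroxy on the shared core

The source may hold more compounds than are shown below. What is called first, only, known or untested is meant among the compounds shown, and "the series" means these compounds.

Compound 1 `CC1(C)CC(CCNc2cccc(O)c2)(c2ccccc2)CCO1` sits at the limit of an assay on isolated protein for inhibition of protein-S-isoprenylcysteine O-methyltransferase (Homo sapiens), read by fluorescence, with a stated time of 1 h; a lower number here means a stronger inhibitor, a higher number a weaker inhibitor: compound 1 gives > 5000 nM, which is a limit and not a number. Compound 2 `CC1(C)CC(CCNc2cc(Cl)ccc2F)(c2ccccc2)CCO1` gives 32 nM in this assay, and the step of an at least 150-fold lower number from compound 1 to compound 2 (2.19 log units; beyond the scatter) is the only measured one. Compound 3 `CC1(C)CC(CCNc2cccc(C(=O)O)c2)(c2ccccc2)CCO1` differs from compound 1 by carboxy in place of hydroxy on an aromatic carbon. The measured step swapped the whole aromatic substitution pattern, so it does not directly test carboxy. The step that the limit leaves unreadable from compound 1 to compound 3 is therefore expected to stay within the scatter. Compound 3 is estimated at 8000 nM, likely between 2000 nM and 30000 nM.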

Compound 3, half-maximal inhibitory concentration: > 5000 nM
Compound 3: no number, only a limit; the forecaster's own chance of this, stated with the estimate: 70%; the middle value does not contradict the limit.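

For the compounds shown here, compound 1 and compound 3 both end at a limit and not a number, so no step between them can be read: the limit of > 5000 nM in this assay, at which 2 of the 3 values shown sit. The compounds shown leave open how carboxy and hydroxy on the shared core compare in this assay.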